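Swapping the allyl for a propargyl ether

This account rests on a few compounds, and the source may have more. Where it says the series, first, only, none or still open, it means among the compounds named here.

Measured so far in a functional assay on HepG2 cells (Homo sapiens) for antiproliferative activity, read by MTT assay, with a stated time of 24 h; a lower number here means a stronger inhibitor, a higher number a weaker inhibitor:
Compound 1 `COc1cc(OC)c(-c2coc3cc(OCC=C(C)C)ccc3c2=O)cc1OC` gives 280 nM
Compound 2 `C=CCOc1ccc2c(=O)c(-c3cc(OC)c(OC)cc3OC)coc2c1` gives 3450 nM

Compound 2 stands at 3450 nM as the higher of the two numbers, and compound 1 gives 280 nM on the same scale. Compound 3 `C#CCOc1ccc2c(=O)c(-c3cc(OC)c(OC)cc3OC)coc2c1` differs from compound 2 by a single change ethynyl in place of vinyl on a saturated chain carbon bound to an oxygen on an aromatic ring with ethynyl in place of vinyl on a saturated chain carbon bound to an oxygen on an aromatic ring. Within the data shown here, the only measured step at this place is a 12-fold higher number from compound 1 to compound 2 (1.09 log units; beyond the scatter) and it is large. Among the measured compounds shown here, that step exchanges 2-methylprop-1-en-1-yl for vinyl, a different change, and no measured compound carries ethynyl. It shows that the number can move at this place but gives no direction for the new exchange. Starting from compound 2 at 3450 nM, no step beyond the scatter is expected in this assay for this exchange. The estimated change is a 1.2-fold lower number from compound 2 to compound 3 (0.06 log units; within the scatter) by this reckoning. The value expected for compound 3 is 3000 nM (estimated range 1000 nM to 9000 nM).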

Compound 3, half-maximal inhibitory concentration: 4950 nM
The estimate for compound 3 lay 1.7-fold (0.22 log units) below the measured number; low and high end bracket the measured number.
By their numbers in this assay, from the lowest: compound 1; then compounds 2 and 3 (each within the scatter of the next).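

In this assay the exchange of vinyl for ethynyl gives a 1.4-fold higher number from compound 2 to compound 3 (0.16 log units; within the scatter) and so does not separate the allyloxy and propargyloxy ethers at this place. The exchange of 2-methylprop-1-en-1-yl for ethynyl gives an 18-fold higher number from compound 1 to compound 3 (1.25 log units; beyond the scatter) and stands with the earlier 12-fold higher number from compound 1 to compound 2 (1.09 log units; beyond the scatter) as a second large step, so among these three ethers the large difference lies between the 2-methylprop-1-en-1-yl ether and the two shorter ones, with either short end. Nothing at hand accounts for this difference.

The three compounds do not separate the chain length of compound 1 from its two terminal methyl groups, and a plain saturated chain such as pentyl would bear on that question. From the compounds shown here alone, whether an amine or a carboxylic acid at the chain end would be tolerated also remains open.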